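Pyridinyl swap on a trimethoxybenzylidene piperidinone series

The compounds below may be only part of what the source reports. "The series", "measured", "known", "first", "only" and "open" are said of these compounds alone.

Measured compounds in a functional assay on QGY-7703 cells (Homo sapiens) for cytotoxicity, read by MTT assay, with a stated time of 24 h; on this read-out higher numbers stand for weaker inhibition and lower numbers for stronger inhibition:
- compound 1 `COc1cc(/C=C2\CN(C)C/C(=C\c3cccnc3)C2=O)cc(OC)c1OC` gives 4300 nM
- compound 2 `COc1ccc(/C=C2\CN(C)C/C(=C\c3cccnc3)C2=O)c(OC)c1OC` gives 2630 nM
- compound 3 `COc1cc(/C=C2\CN(C)C/C(=C\c3ccncc3)C2=O)cc(OC)c1OC` gives 5900 nM

Compound 4 `COc1ccc(/C=C2\CN(C)C/C(=C\c3ccncc3)C2=O)c(OC)c1OC` is not yet measured in this assay.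

The cores of compound 1 and compound 2 differ, but how they differ is not broken down here. Compound 3 carries pyridin-4-yl in place of pyridin-3-yl on a double-bonded chain carbon bound to a double-bonded ring carbon relative to compound 1, and that step gave a 1.4-fold higher number from compound 1 to compound 3 (0.14 log units; within the scatter). Compound 4 carries the same change relative to compound 2, namely (pyridin-4-yl in place of pyridin-3-yl on a double-bonded chain carbon bound to a double-bonded ring carbon), at the same place. The values of compound 2 and compound 3 sit beyond the scatter of each other; those of compound 1 and compound 2 do not.

For compound 4 a step of about a 1.4-fold higher number from compound 2 to compound 4 (0.15 log units; within the scatter) is expected, because a 1.4-fold higher number from compound 1 to compound 3 (0.14 log units; within the scatter) shows this same change barely moving the number. Compound 4 is therefore estimated at 3700 nM, between 2000 nM and 7000 nM.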

Compound 4, half-maximal inhibitory concentration: 8350 nM
For compound 4 the middle estimate is 2.3-fold (0.35 log units) below the measured one, and the stated range ends below it.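

In this assay, pyridin-4-yl in place of pyridin-3-yl gives a 3.2-fold higher number from compound 2 to compound 4 (0.50 log units; beyond the scatter), while the same change on the core of compound 1 gives a 1.4-fold higher number from compound 1 to compound 3 (0.14 log units; within the scatter). Set side by side, the two steps do not differ beyond what the scatter of two such steps allows: the same change on two cores in this assay, a 1.4-fold higher number (0.14 log units; within the scatter) from compound 1 to compound 3 and a 3.2-fold higher number (0.50 log units; beyond the scatter) from compound 2 to compound 4, 2.3-fold (0.36 log units) apart, within the scatter of two such steps The change can therefore be carried between these two cores as one step of uncertain size, but two pairs do not show that its size is the same on both cores, or that it would hold on any other core.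

The compounds shown leave open how pyridin-2-yl, or a phenyl ring carrying an amine, would read in that place on either core.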